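From Sulfoxide to Ketone: One Change Awaiting a Number

The source may report more compounds than this note shows. Statements on the series, on what has been measured and on what is new or still open speak of the compounds shown alone.

In an assay for inhibition of 15-hydroxyprostaglandin dehydrogenase [NAD(+)] (Homo sapiens), read by fluorescence, with a stated time of 15 min, in the presence of a further agent that is not named here (on this read-out lower numbers stand for stronger inhibition and higher numbers for weaker inhibition), compound 1 `Nc1c([S+]([O-])CCCF)sc2nc(-c3cccs3)cc(-c3ccccc3)c12` gives 6.1 nM. For the measured compounds named here, compound 2 `CCCC[S+]([O-])c1sc2nc(-c3nc(C)cs3)cc(-c3cnc(C)n3C)c2c1N` gives 2.8 nM in the same assay, a lower number that lies beyond the usual scatter, so of the two numbers known, compound 1 stands at the higher one. Compound 3 `CCCC[S+]([O-])c1nc2ccc(-c3cccs3)nc2[nH]1` gives only a limit of the assay, > 7500 nM, not a number. Compound 4 `CCCCC(=O)c1sc2nc(-c3cccs3)cc(-c3ccccc3)c2c1N` is not yet measured; it differs from compound 1 in one place: a group of 6 heavy atoms (5 carbon, 1 oxygen; no ring) in place of a group of 6 heavy atoms (3 carbon, 1 oxygen, 1 fluorine, 1 sulfur; no ring), on an aromatic carbon, in words a group of 6 heavy atoms (5 carbon, 1 oxygen; no ring) in place of a group of 6 heavy atoms (3 carbon, 1 oxygen, 1 fluorine, 1 sulfur; no ring), on an aromatic carbon. Going by the values given here, no measured pair shows a change of this kind, so its size is uncertain. The step expected here is an 8.2-fold higher number from compound 1 to compound 4 (0.91 log units; beyond the scatter), toward a higher number. Compound 4 is estimated at 50 nM, between 8 nM and 400 nM.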

Compound 4, half-maximal inhibitory concentration: > 7500 nM
Compound 4: a limit, no number; the forecaster's own chance of this, stated with the estimate: 10%; middle value at least 150-fold (2.17 log units) from the limit.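

At this position, on an aromatic carbon next to the ring sulfur, putting butylcarbonyl in place of the sulfur-bearing group gives an at least 1200-fold higher number from compound 1 to compound 4 (3.08 log units; beyond the scatter) in this assay. Both groups count 6 heavy atoms and 1 hydrogen-bond acceptor, so matching these counts does not preserve the value here. For compound 4 the value is a limit of the assay, not a number: the limit of > 7500 nM in this assay, at which 2 of the 4 values shown sit.

The step removes the sulfur and the fluorine together, and the compounds shown do not separate the two. Going by these compounds, how a sulfone or an amide would read at this position also remains open.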